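Sulfonamide Phenyl Replaces Methoxybenzyl on the Triazole

The compounds below may be only part of what the source reports. "The series", "measured", "known", "first", "only" and "open" are said of these compounds alone.

Three compounds sharing one core were measured in a functional assay on PC-3 cells (Homo sapiens) for antiproliferative activity, read by MTT assay, with a stated time of 48 h; on this read-out higher numbers stand for weaker inhibition and lower numbers for stronger inhibition. Compound 1 `Brc1ccc(Cn2cc(CSc3nnc(-c4ccccc4)c(-c4ccccc4)n3)nn2)cc1` gave 22000 nM, compound 2 `Cc1ccc(Cn2cc(CSc3nnc(-c4ccccc4)c(-c4ccccc4)n3)nn2)cc1` gave 22600 nM, and compound 3 `COc1ccc(Cn2cc(CSc3nnc(-c4ccccc4)c(-c4ccccc4)n3)nn2)cc1` gave 27500 nM. Compound 3 carries the highest of the three numbers, yet its nearest neighbour is compound 2 and its furthest is compound 1, with both gaps inside the scatter. The three steps that connect them, a 1.0-fold higher number from compound 1 to compound 2 (0.01 log units; within the scatter), a 1.3-fold higher number from compound 1 to compound 3 (0.10 log units; within the scatter) and a 1.2-fold higher number from compound 2 to compound 3 (0.09 log units; within the scatter), all stay within the scatter, so the substituent on that aromatic ring made no visible difference.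

Compound 4 `NS(=O)(=O)c1ccc(-n2cc(CSc3nnc(-c4ccccc4)c(-c4ccccc4)n3)nn2)cc1` differs from compound 3 by 4-sulfamoylphenyl in place of 4-methoxybenzyl on an aromatic nitrogen. Going by the values given here, none of the measured steps alters the group on that aromatic nitrogen in this way; they only swap one substituent for another on the same ring, and each was within the scatter. Among the compounds with values here, with no step bearing directly on this change, the expectation for compound 4 in this assay is a number close to that of compound 3, and the estimated step of a 1.1-fold lower number from compound 3 to compound 4 (0.04 log units; within the scatter) is expected to fall within the scatter. Compound 4 is therefore estimated at 25000 nM, with a range from 8000 nM to 80000 nM.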

Compound 4, half-maximal inhibitory concentration: > 100000 nM
Compound 4: a limit, no number; the forecaster's own chance of this, stated with the estimate: 20%; at least 4.0-fold (0.60 log units) between middle value and limit.
By their numbers in this assay, from the lowest: compounds 1, 2 and 3 (each within the scatter of the next). At a limit, above all of these: compound 4.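

In this assay, compound 4 gives a limit of the assay and not a number: the limit of > 100000 nM in this assay, at which 1 of the 4 values shown sits. Swaps of the substituent on the benzyl ring had stayed within the scatter, but replacing the whole group on the aromatic nitrogen gives an at least 3.6-fold higher number from compound 3 to compound 4 (0.56 log units; beyond the scatter), an at least 4.4-fold higher number from compound 2 to compound 4 (0.64 log units; beyond the scatter) and an at least 4.5-fold higher number from compound 1 to compound 4 (0.65 log units; beyond the scatter), so this position does respond to change. This single replacement alters both the substituent on the ring and the way the ring is linked to the nitrogen, and the data do not separate the two.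

The compounds shown leave open how a 4-sulfamoylbenzyl or a 4-methoxyphenyl group would read on that nitrogen. They also leave open whether a phenyl ring carrying an amine or a carboxylic acid would behave like the 4-sulfamoylphenyl group.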